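This account rests on a few compounds, and the source may have more. Where it says the series, first, only, none or still open, it means among the compounds named here.

Measured in a functional assay on Jurkat cells (Homo sapiens) for cytotoxicity, read by MTT assay, with a stated time of 72 h; a higher number here means a weaker inhibitor, a lower number a stronger inhibitor:
- compound 1 `COC(=O)c1sc2c(C)cccc2c1Nc1cc(OC)c(OC)c(OC)c1`: 1630 nM
- compound 2 `COC(=O)c1sc2cc(OC)ccc2c1Nc1cc(OC)c(OC)c(OC)c1`: 1.7 nM
- compound 3 `CCOC(=O)c1sc2ccccc2c1Nc1cc(OC)c(OC)c(OC)c1`: 3020 nM

Compound 3, at 3020 nM, lies within the scatter of compound 1, at 1630 nM. Compound 2 gives 1.7 nM, a much lower number and beyond the scatter from both.

Compound 4 `CCOC(=O)c1sc2cccc(C)c2c1Nc1cc(OC)c(OC)c(OC)c1` differs from compound 3 in one place: methyl in place of hydrogen on an aromatic carbon. Among the measured compounds shown here, no pair of measured compounds isolates this change, so the expectation rests on indirect evidence. Compound 1 also carries a methyl on the shared core and gives 1630 nM, although its ester differs and its methyl sits elsewhere. The low number of compound 2 comes with a methoxy group and not a methyl, so it offers little guide here.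

The expected change is small and within the scatter, with a 1.2-fold lower number from compound 3 to compound 4 (0.08 log units; within the scatter) as the estimated step. Compound 4 is expected at 2500 nM, with an estimated range of 500 nM to 10000 nM.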

Compound 4, half-maximal inhibitory concentration: 5670 nM
For compound 4 the middle estimate is 2.3-fold (0.36 log units) below the measured one, and the stated range covers the measured number.
By their numbers in this assay, from the lowest: compound 2; then compounds 1, 3 and 4 (each within the scatter of the next, the first and the last beyond it).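

In this assay, methyl in place of hydrogen on an aromatic carbon, ortho to a fused ring and meta to a fused ring, gives a 1.9-fold higher number from compound 3 to compound 4 (0.27 log units; within the scatter) and so stays inside the usual scatter. Among the compounds shown here, this pair is the first to isolate one change, and it shows that a methyl at this position does not separate compound 4 from compound 3 in this cytotoxicity read-out. No measurement at hand speaks to the origin of this step. Going by these compounds, whether an amine, a hydroxyl or a longer chain such as propyl on this same carbon would also stay within the scatter remains open. Also open, on these data alone, is whether the methyl gives a similar step when the ethyl ester is replaced by a carboxylic acid or an amide.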